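From dipropylamino to piperazin-1-yl on a sulfonyl sulfur

The source may report more compounds than this note shows. Statements on the series, on what has been measured and on what is new or still open speak of the compounds shown alone.

Among the compounds with values here, compound 1 (`CCCN(CCC)S(=O)(=O)c1ccc(S(=O)(=O)N2CCC[C@@H](C(=O)OCC)C2)cc1`) gives 2500 nM in a functional assay on BXPC-3 cells (Homo sapiens) for inhibition, read by MTT assay, with a stated time of 7 days (a higher number here means a weaker inhibitor, a lower number a stronger inhibitor), and so holds the only true number available so far. In this assay compound 2 (`CCOC(=O)N1CCC[C@@H](S(=O)(=O)c2ccc(S(=O)(=O)N(CC)CC)cc2)C1`) reads > 30000 nM as a limit of the assay and not as a number. Compound 3 (`CCOC(=O)[C@@H]1CCCN(S(=O)(=O)c2ccc(S(=O)(=O)N3CCNCC3)cc2)C1`) keeps the core of compound 1 and differs from it in one place. The change (piperazin-1-yl in place of dipropylamino on a sulfonyl sulfur) puts piperazin-1-yl in place of dipropylamino on a sulfonyl sulfur, so the group that enters is a ring and carries a hydrogen-bond donor, while the group that leaves has neither. Within the data shown here, no measured pair shows what this change does, so the expectation starts from compound 1 at 2500 nM and carries real uncertainty. In this assay a loss of inhibition beyond the scatter is expected, with the estimated move (a 3.6-fold higher number from compound 1 to compound 3 (0.56 log units; beyond the scatter)) going toward a higher number. Compound 3 is expected at about 9000 nM within an estimated range from 2500 nM to 30000 nM and may also return only as a limit.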

Compound 3, half-maximal inhibitory concentration: > 30000 nM
Compound 3 was reported as a limit; the forecaster's own chance of this, stated with the estimate: 25%; middle value at least 3.3-fold (0.52 log units) away from the limit.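

Within the data shown here, on the sulfonyl sulfur whose other neighbour is an aromatic carbon, this is the first single change that can be read in this assay, and replacing dipropylamino with piperazin-1-yl gives a large loss of inhibition: an at least 12-fold higher number from compound 1 to compound 3 (1.07 log units; beyond the scatter). Compound 3 reads > 30000 nM, which is a limit of the assay and not a number. The step therefore gives only a minimum size, and the true gap cannot be read because compound 3 stands at the limit of the assay: the limit of > 30000 nM in this assay, at which 2 of the 3 values shown sit.

The change brings in a ring and a hydrogen-bond donor together, and this one step does not show which of them goes with the loss, or whether the removal of the two propyl chains does. A piperidin-1-yl group on this sulfur, with the ring but no second nitrogen, or a 4-methylpiperazin-1-yl group, with the second nitrogen but no hydrogen on it, would help to separate these readings on the core of compound 1.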